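The source may hold more compounds than are shown below. What is called first, only, known or untested is meant among the compounds shown, and "the series" means these compounds.

Measured so far in an in vitro assay on Sf21 cells for inhibition of high affinity 3',5'-cyclic-AMP phosphodiesterase 7A (Homo sapiens); a lower number here means a stronger inhibitor, a higher number a weaker inhibitor:

compound 1 `CNc1nc(NC2(C#N)CCCCC2)nc(N(C)C)n1`: > 5000 nM.

compound 2 `CNc1nc(Cl)nc(NC2(C#N)CCCCC2)n1`: 1070 nM.

compound 3 `CNc1nc(NC2(C#N)CCCCC2)nc(-n2cnc(C#N)n2)n1`: > 5000 nM.

Compound 1 stands at > 5000 nM, which is a limit of this assay, not a number. The same holds for compound 3 at > 5000 nM. Going by the values given here, compound 1 therefore stands at the limit of > 5000 nM in this assay, at which 2 of the 3 values shown sit, and the only number in the set is that of compound 2, at 1070 nM.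

The unmeasured compound 4 `CNc1nc(NC2(C#N)CCCCC2)nc(C2CC2)n1` differs from compound 1 by cyclopropyl in place of dimethylamino on an aromatic carbon.

Among the compounds with values here, the steps that bear on it all run through the same aromatic carbon. Exchanging dimethylamino for chloro gave an at least 4.6-fold lower number from compound 1 to compound 2 (0.66 log units; beyond the scatter). Exchanging chloro for 3-cyano-1H-1,2,4-triazol-1-yl gave an at least 4.6-fold higher number from compound 2 to compound 3 (0.66 log units; beyond the scatter), back to the limit. Between the two limits the step that the two limits leave unreadable from compound 1 to compound 3 cannot be read. Cyclopropyl, like chloro, is a small group at this carbon, whereas the larger 3-cyano-1H-1,2,4-triazol-1-yl returned a limit, so the expectation in this assay is a lower number than for compound 1, of about the size of the step to compound 2 or somewhat smaller, and not a higher one. The expected step is an at least 2.5-fold lower number from compound 1 to compound 4 (0.39 log units; beyond the scatter). For compound 4 the estimate in this assay is 2000 nM, within 600 nM to 7000 nM.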

Compound 4, half-maximal inhibitory concentration: 539 nM
The estimate for compound 4 lay 3.7-fold (0.57 log units) above the measured number, outside the stated range (below it).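

In this assay, cyclopropyl in place of dimethylamino gives an at least 9.2-fold lower number from compound 1 to compound 4 (0.96 log units; beyond the scatter); both groups count 3 heavy atoms, so in this pair the heavy-atom count at this aromatic carbon does not by itself set the read-out. The change from the triazole-linked group gives an at least 9.2-fold lower number from compound 3 to compound 4 (0.96 log units; beyond the scatter), while cyclopropyl in place of chloro gives a 2.0-fold lower number from compound 2 to compound 4 (0.30 log units; within the scatter), so the carbon-linked ring and chloro cannot be told apart in this assay. Compound 1 and compound 3 each sit at a limit and not at a number, so the first two steps are only bounds on the true size: the limit of > 5000 nM in this assay, at which 2 of the 4 values shown sit.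

Compound 4 differs from compound 1 both in gaining a ring of carbon only and in losing a hydrogen-bond acceptor at this carbon, and the compounds shown do not separate these two differences. Going by these compounds, how a methyl, an isopropyl or a methoxy group at this carbon would read stays open, as does whether a cyclobutyl ring would keep, lower or raise the number seen with cyclopropyl.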